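Methoxy in Place of Methyl: What Compound 4 Might Show

This account rests on a few compounds, and the source may have more. Where it says the series, first, only, none or still open, it means among the compounds named here.

Three compounds were measured in a functional assay on the whole organism (strain L.) for inhibition, with Echinochloa crus-galli as the target, with a stated time of 72 h, tested at 10 mg/L; a higher number here means more inhibition of growth at the concentration tested, a lower number less inhibition of growth. Compound 1 `COc1cc(C)nc2n/c(=N/C(=O)c3c(-c4ccc(Cl)cc4Cl)noc3C)sn12` gives 30.9%, the highest of the three. Compound 2 `COc1cc(Cl)nc(NC(=S)NC(=O)c2c(-c3ccc(Cl)cc3Cl)noc2C)n1` gives 18.5%, and compound 3 `Cc1cc(Cl)nc(NC(=S)NC(=O)c2c(-c3ccc(Cl)cc3Cl)noc2C)n1` gives -6.84%.

Compounds 3 and 2 differ in one place (methoxy in place of methyl on an aromatic carbon), and this change produced a step of a number 25.3 percentage points higher from compound 3 to compound 2 (beyond the scatter).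

Compound 4 `COc1cc(OC)n2s/c(=N\C(=O)c3c(-c4ccc(Cl)cc4Cl)noc3C)nc2n1` has not yet been measured. It differs from compound 1 by methoxy in place of methyl on an aromatic carbon. This is the same kind of change as that from compound 3 to compound 2, but not the same: in compound 4 the place is part of a fused or bridged system of two rings, meta to a fused ring, meta to a methoxy group and para to a fused ring, whereas in compound 2 it is meta to a chloro group and meta to a large group. The difference between the two cores is not broken down here.

Resting on the step of a number 25.3 percentage points higher from compound 3 to compound 2 (beyond the scatter) and on the value of compound 1 in this assay, 30.9%, the step from compound 1 to compound 4 is expected to be a number 15.1 percentage points higher from compound 1 to compound 4 (beyond the scatter), somewhat smaller since the surroundings differ. Compound 4 is therefore estimated at 46%, between 25% and 70%.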

Compound 4, percent growth inhibition at one concentration: 43.2%
Compound 4: the middle estimate sits 2.8 percentage points above what was measured; the range from low to high includes it.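

In this assay, methoxy in place of methyl on an aromatic carbon again gave more inhibition of growth, with a number 12.3 percentage points higher from compound 1 to compound 4 (beyond the scatter) on the core of compound 1. The change therefore carried over in direction, and the two steps cannot be told apart in size: the same change on two cores in this assay, a number 25.3 percentage points higher (beyond the scatter) from compound 3 to compound 2 and a number 12.3 percentage points higher (beyond the scatter) from compound 1 to compound 4, 13 percentage points apart, within the scatter of two such steps. Within the data shown here, this rests on only two pairs, so it shows that the gain held on these two cores, but not that it would hold on a further core or at another place on the ring, and it gives no reason for the gain.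

The compounds shown leave open whether another group in the same place, such as an amine, a carboxylic acid or a longer chain like butoxy, would give a step of similar direction. They also leave open whether the step would persist if the dichlorophenyl group shared by all four compounds were replaced, for example by an unsubstituted phenyl.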